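The source may report more compounds than this note shows. Statements on the series, on what has been measured and on what is new or still open speak of the compounds shown alone.

Working notes on the series.

The shared core is a bicyclic double N-oxide bearing an amine-linked ether chain; compound 1 `CCCCCOCNc1n[n+]([O-])c2ccccc2[n+]1[O-]` carries the pentyloxy chain. In a functional assay on SMMC-7721 cells (Homo sapiens) for cytotoxicity, read by MTT assay, with a stated time of 72 h (a higher number here means a weaker inhibitor, a lower number a stronger inhibitor), compound 1 gives 3050 nM, the highest number of the three measured. For the measured compounds named here, compound 2 `[O-][n+]1nc(NCOCc2ccc(C(F)(F)F)cc2)[n+]([O-])c2ccccc21` gives 780 nM in this assay, and compound 3 `CCCCCOCNc1n[n+]([O-])c2cc(OC)ccc2[n+]1[O-]` gives 550 nM; the only single-point step in hand is a 5.5-fold lower number from compound 1 to compound 3 (0.74 log units; beyond the scatter). Compound 2 differs from compound 1 in more than one place, so its value tells nothing about any one change.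

Compound 4 `CC(C)CCOCNc1n[n+]([O-])c2ccccc2[n+]1[O-]` is the next candidate, differing from compound 1 by isopropyl in place of propyl on a saturated chain carbon, two bonds along the chain from an oxygen on a saturated carbon. Neither measured step bears on this change: the step to compound 3 concerns a methoxy on an aromatic carbon, and compound 2 changes the chain in several places at once. With no guidance from the measured compounds, the branching of the chain end is expected to leave this assay about where compound 1 stands, with no step beyond the scatter, so that for compound 4 the expected step is a 1.0-fold lower number from compound 1 to compound 4 (0.01 log units; within the scatter). The estimated value for compound 4 in this assay is 3000 nM, within a range of 1200 nM to 7500 nM.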

Compound 4, half-maximal inhibitory concentration: 2860 nM
For compound 4 the middle estimate is 1.0-fold (0.02 log units) above the measured one; the range from low to high includes it.
By their numbers in this assay, from the lowest: compounds 3 and 2 (each within the scatter of the next); then compounds 4 and 1 (each within the scatter of the next).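

In this assay, isopropyl in place of propyl on a saturated chain carbon, two bonds along the chain from an oxygen on a saturated carbon, gives a 1.1-fold lower number from compound 1 to compound 4 (0.03 log units; within the scatter). For the compounds shown here, this is the first single-place reading on the chain itself, since the earlier step, a 5.5-fold lower number from compound 1 to compound 3 (0.74 log units; beyond the scatter), concerned a methoxy on an aromatic carbon; at this position, the same atoms joined differently show no step beyond the scatter. No supporting information on this result is available to account for it.

From the compounds shown here alone, it remains open whether a longer chain, a cyclohexyl group or an amine at this position would give a step beyond the scatter. Going by these compounds, it also remains open whether the methoxy step seen on the pentyloxy chain carries over to the isopentyloxy chain of compound 4.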